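The compounds below may be only part of what the source reports. "The series", "measured", "known", "first", "only" and "open" are said of these compounds alone.

Compound 1 `CN1CCN(c2ccc(S(=O)(=O)Oc3cccc(F)c3)cc2)C1=O` and compound 2 `CN1CCN(c2ccc(S(=O)(=O)Oc3cccc(Br)c3)cc2)C1=O` share a core; compound 3 `CCCCN1CCN(c2ccc(S(=O)(=O)Oc3cccc(F)c3)cc2)C1=O` and compound 4 `CCCCN1CCN(c2ccc(S(=O)(=O)Oc3cccc(Br)c3)cc2)C1=O` share another, which differs from the first by propyl in place of hydrogen on a saturated chain carbon bound to an amide-type nitrogen in a ring. In a functional assay on HT-29 cells (Homo sapiens) for antiproliferative activity, read by sulforhodamine B assay, with a stated time of 48 h (on this read-out lower numbers stand for stronger inhibition and higher numbers for weaker inhibition), compound 1 gives only a limit, > 100000 nM (the limit of > 100000 nM in this assay, at which 1 of the 3 values shown sits). Compound 2 gives 1300 nM, and compound 3 gives 76000 nM, so that an at least 1.3-fold lower number from compound 1 to compound 3 (0.11 log units; that floor lies within the scatter). The change bromo in place of fluoro on an aromatic carbon yields an at least 76-fold lower number from compound 1 to compound 2 (1.88 log units; beyond the scatter). The same change, (bromo in place of fluoro on an aromatic carbon), now leads from compound 3 to compound 4, and the place of the change is the same in both pairs. Resting on the step from compound 1 to compound 2, compound 4 is expected to show a 51-fold lower number from compound 3 to compound 4 (1.70 log units; beyond the scatter) in this assay. Compound 4 is therefore estimated at 1500 nM, with a likely range from 300 nM to 8000 nM.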

Compound 4, half-maximal inhibitory concentration: 16000 nM
The estimate for compound 4 lay 11-fold (1.03 log units) below the measured number; measured number outside the range, above it.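

In this assay, bromo in place of fluoro still gives a lower number on the second core, with a 4.8-fold lower number from compound 3 to compound 4 (0.68 log units; beyond the scatter), but the size of the step does not carry over: the same change on two cores in this assay, an at least 76-fold lower number (1.88 log units; beyond the scatter) from compound 1 to compound 2 and a 4.8-fold lower number (0.68 log units; beyond the scatter) from compound 3 to compound 4, at least 16-fold (1.20 log units) apart, beyond the scatter of two such steps

The propyl change likewise depends on which halogen is present, with a 12-fold higher number from compound 2 to compound 4 (1.09 log units; beyond the scatter): the same change on two cores in this assay, an at least 1.3-fold lower number (0.11 log units; that floor lies within the scatter) from compound 1 to compound 3 and a 12-fold higher number (1.09 log units; beyond the scatter) from compound 2 to compound 4, at least 16-fold (1.20 log units) apart, beyond the scatter of two such steps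

What this does not show is the true size of the step on the first core, for which compound 1 gives only a limit: the limit of > 100000 nM in this assay, at which 1 of the 4 values shown sits.

The compounds shown leave open how the bromo change behaves with a longer chain, such as hexyl, or with an amine-bearing chain on the amide-type nitrogen. They also leave open whether chloro or iodo would follow bromo.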